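The source may report more compounds than this note shows. Statements on the series, on what has been measured and on what is new or still open speak of the compounds shown alone.

Compound 1 `COC(=O)c1ccc(-c2cnc(C(=O)CCCCCCc3ccccc3)o2)nc1` gives 3.5 nM in an assay (Rattus norvegicus) for inhibition of Fatty-acid amide hydrolase 1 (Homo sapiens); on this read-out higher numbers stand for weaker inhibition and lower numbers for stronger inhibition. Compound 2 `NC(=O)c1ccc(-c2cnc(C(=O)CCCCCCc3ccccc3)o2)nc1` gives 1.2 nM in this assay. The change amino in place of methoxy on a carbonyl carbon produces the step of a 2.9-fold lower number from compound 1 to compound 2 (0.46 log units; beyond the scatter). Compound 3 `COC(=O)c1cnc(C(O)CCCCCCc2ccccc2)o1` gives 2000 nM in this assay and carries the highest of the three numbers. Within the data shown here, the difference between the core of compound 3 and the core of compound 1 is not broken down here; the two numbers show only that compound 3 stands far weaker than compound 1 and compound 2. Compound 4 `NC(=O)c1cnc(C(O)CCCCCCc2ccccc2)o1` is not yet measured in this assay. Among the measured compounds shown here, it differs from compound 3 by amino in place of methoxy on a carbonyl carbon, the same change as the one separating compound 1 and compound 2, at a place described in the same words. The step from compound 3 to compound 4 in this assay is expected to be a 2.5-fold lower number from compound 3 to compound 4 (0.40 log units; beyond the scatter), resting on the earlier step of a 2.9-fold lower number from compound 1 to compound 2 (0.46 log units; beyond the scatter); a single precedent on a different core is a thin basis, so the range is kept wide. Compound 4 is expected to give 800 nM, between 300 nM and 2500 nM.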

Compound 4, inhibition constant: 25000 nM
The estimate for compound 4 lay 31-fold (1.49 log units) below the measured number; the whole stated range lies below it.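

On the core of compound 3, amino in place of methoxy on a carbonyl carbon gives a 13-fold higher number from compound 3 to compound 4 (1.10 log units; beyond the scatter) in this assay, so the change does not run the same way as on the core of compound 1. The two steps point in opposite directions and do not agree within the scatter: the same change on two cores in this assay, a 2.9-fold lower number (0.46 log units; beyond the scatter) from compound 1 to compound 2 and a 13-fold higher number (1.10 log units; beyond the scatter) from compound 3 to compound 4, 36-fold (1.56 log units) apart, beyond the scatter of two such steps

For these two pairs, then, the step measured on one core gave no usable guide to the step on the other, in direction or in size; this does not show which difference between the cores is responsible, since that difference is not broken down, and two pairs set no rule for any further core.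

Open, as far as these compounds go, is whether the change keeps either direction on a core differing from compound 3 or compound 1 in one place only. Also open, from the compounds shown here alone, is how a carboxylic acid or a nitrile in place of the methoxycarbonyl group would stand on each core.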